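The compounds below may be only part of what the source reports. "The series", "measured", "known", "first", "only" and "open" are said of these compounds alone.

Measured compounds:
compound 1 `C[C@H](NC(=O)c1c(Cc2cc(F)c(Cl)cc2Cl)sc2c1CCOC2)c1ccc(C(=O)O)cc1`: 2.5 nM
compound 2 `O=C(NCC1CCC(C(=O)O)CC1)c1c(Cc2ccc(F)cc2)sc2c1CCOC2`: 30.3 nM

Among the measured compounds shown here, both compounds share the same core and have been tested in a functional assay on CHO/Galpha16 cells for antagonist activity at prostaglandin E2 receptor EP4 subtype (Homo sapiens), read by calcium flux, with a stated time of 15 min; on this read-out lower numbers stand for stronger inhibition and higher numbers for weaker inhibition. Compound 1 gives 2.5 nM, the lowest of the two numbers. Compound 2 gives 30.3 nM, a higher number, and the gap between the two lies beyond the usual scatter of repeated measurements.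

Compound 3 `COc1ccc(Cc2sc3c(c2C(=O)N[C@@H](C)c2ccc(C(=O)O)cc2)CCOC3)cc1` has not yet been measured. It differs from compound 1 in one place: 4-methoxyphenyl in place of 2,4-dichloro-5-fluorophenyl on a saturated chain carbon bound to an aromatic carbon. Compound 2 also carries a different group on that saturated chain carbon, but it differs from compound 1 in its amine part as well, so it gives no clean reading of this single change.

With only this to go on, the step from compound 1 to compound 3 in this assay is expected to be a moderate rise in the number, that is somewhat weaker inhibition: a 4.0-fold higher number from compound 1 to compound 3 (0.60 log units; beyond the scatter). Compound 3 is therefore estimated at 10 nM, within a range of 3 nM to 40 nM.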

Compound 3, half-maximal inhibitory concentration: 2.1 nM
Beside the measured number, compound 3's estimate is 4.8-fold (0.68 log units) above it, outside the stated range (below it).
By their numbers in this assay, from the lowest: compounds 3 and 1 (each within the scatter of the next); then compound 2.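

In this assay, putting 4-methoxyphenyl in place of 2,4-dichloro-5-fluorophenyl on a saturated chain carbon bound to an aromatic carbon gives a 1.2-fold lower number from compound 1 to compound 3 (0.08 log units; within the scatter). With the amine part held fixed, this position therefore takes two quite different aryl groups without a difference that stands out from the scatter, and the chlorine and fluorine atoms of compound 1 are not needed for a number this low, since compound 3 carries neither element and has an oxygen instead. Nothing measured here accounts for why these two groups read alike.

Two compounds cannot show whether any aryl group would do at this position, or whether the methoxy group and the halogens each happen to support the same level of inhibition, and a plain phenyl or a 4-ethoxyphenyl group on the same carbon would help to separate these possibilities. On these data alone, the contribution of the amine part also stays open, as compound 2 differs from compound 1 in more than one place and so cannot isolate the effect of either change.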